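A few compounds are considered here, and "the series" means these few. Any claim that something is new, unique, unknown or untested is made for them only; others in the source may bear on it.

Compound 1 `O=C(Nc1cccc(-n2cc(-c3ccncc3)c(-c3cc(O)cc(Cl)c3)n2)c1)Nc1ccc(Cl)c(C(F)(F)F)c1` gives -15% in a functional assay on SK-OV-3 cells (Homo sapiens) for inhibition, read by sulforhodamine B assay, with a stated time of 48 h, tested at 100 uM (on this read-out higher numbers stand for a weaker effect at the one concentration tested and lower numbers for a stronger effect), and stands highest of the two numbers, with compound 2 `O=C(Nc1cccc(-n2cc(-c3ccncc3)c(-c3cc(O)cc(Cl)c3)n2)c1)Nc1ccc(Cl)c(Cl)c1` giving -22%, the step of a number 7 percentage points lower from compound 1 to compound 2 (within the scatter) being within the scatter. Compound 3 `COc1cc(Cl)cc(-c2nn(-c3cccc(NC(=O)Nc4ccc(Cl)c(C(F)(F)F)c4)c3)cc2-c2ccncc2)c1` differs from compound 1 by methyl in place of hydrogen on an oxygen on an aromatic ring. Among the measured compounds shown here, no measured step touches the hydroxy-to-methoxy change; the one step known, a number 7 percentage points lower from compound 1 to compound 2 (within the scatter), sits on a different part of the molecule and was within the scatter. No step beyond the scatter is therefore expected for compound 3, whose estimated result is -12% within -35% to 12%, an expected step of a number 3 percentage points higher from compound 1 to compound 3 (within the scatter).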

Compound 3, a percentage reported as activity, at one concentration (the size of the read-out at that concentration, not a potency): -39%
The estimate for compound 3 lay 27 percentage points above the measured number, and the stated range ends above it.
By their numbers in this assay, from the lowest: compound 3; then compounds 2 and 1 (each within the scatter of the next).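

Hydroxy to methoxy on the 3-chloro-5-hydroxyphenyl group moves the number in this assay beyond the scatter, a step towards a stronger effect at the one concentration tested: a number 24 percentage points lower from compound 1 to compound 3 (beyond the scatter). The free hydrogen on this oxygen is therefore not required for the effect at this concentration, and this position responds more than the chloro for trifluoromethyl change, a number 7 percentage points lower from compound 1 to compound 2 (within the scatter). No measurement at hand accounts for the step.

As far as these compounds go, whether the step is specific to methoxy stays open; ethoxy or an amine at this place would test that. Also open, from the compounds shown here alone, is whether it carries over to compound 2.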